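Hydroxy in Place of Trifluoromethyl: Expecting Little Change

The source may report more compounds than this note shows. Statements on the series, on what has been measured and on what is new or still open speak of the compounds shown alone.

Of the compounds shown here, three sharing one core have been tested in a functional assay on PC-3 cells (Homo sapiens) for cytotoxicity, read by sulforhodamine B assay, with a stated time of 72 h; a lower number here means a stronger inhibitor of growth, a higher number a weaker inhibitor of growth. Compound 1 `CC(=O)N1c2ccccc2CCC1C(=O)Nc1ccccc1O` gives 70700 nM in this assay. Compound 2 `O=C(Nc1ccccc1O)C1CCc2ccccc2N1C(=O)c1ccccc1Cl` carries a 2-chlorophenyl in place of methyl on a carbonyl carbon and gives 60000 nM. The step of a 1.2-fold lower number from compound 1 to compound 2 (0.07 log units; within the scatter) is within the scatter. Compound 3 `O=C(Nc1ccccc1C(F)(F)F)C1CCc2ccccc2N1` gives 53300 nM in this assay. It has the lowest of the three numbers, but its gap to compound 2 and its gap to compound 1 are both within the scatter, so the three compounds cannot be told apart on these data.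

Compound 4 `O=C(Nc1ccccc1O)C1CCc2ccccc2N1` has not yet been measured. It differs from compound 3 by hydroxy in place of trifluoromethyl on an aromatic carbon. Among the compounds with values here, no measured step concerns this change directly. Within the data shown here, the only measured step, a 1.2-fold lower number from compound 1 to compound 2 (0.07 log units; within the scatter), concerns the group on the carbonyl carbon and was within the scatter. Compounds 1 and 2, which both carry the hydroxy, sit within the scatter of compound 3. The expected step of a 1.1-fold higher number from compound 3 to compound 4 (0.04 log units; within the scatter) is therefore none beyond the scatter. Compound 4 is estimated at 58000 nM, with an expected range from 25000 nM to 130000 nM in this assay.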

Compound 4, concentration for 50% growth inhibition: 4310 nM
Compound 4: the middle estimate sits 13-fold (1.13 log units) above what was measured, and the stated range ends above it.
By their numbers in this assay, from the lowest: compound 4; then compounds 3, 2 and 1 (each within the scatter of the next).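

In this assay the aromatic carbon proves sensitive to its group once the nitrogen of the core carries hydrogen, with hydroxy in place of trifluoromethyl giving a 12-fold lower number from compound 3 to compound 4 (1.09 log units; beyond the scatter) as a large step. The hydroxy alone does not give this result: compound 1 and compound 2 both carry it, yet removing the acyl group from that nitrogen gives a 16-fold lower number from compound 1 to compound 4 (1.21 log units; beyond the scatter) and a 14-fold lower number from compound 2 to compound 4 (1.14 log units; beyond the scatter) as equally large steps. Of these four compounds, only compound 4 combines the hydroxy with that free nitrogen, and it alone stands apart from the rest. Nothing shown here accounts for the size of these steps.

The compounds shown leave open whether a methoxy or an amine on the same aromatic carbon would keep the number of compound 4. They also leave open whether a methyl on the nitrogen of the core would be tolerated where the two acyl groups were not.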